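Replacing a sulfur-linked ring with an ethylpiperazine

The source may report more compounds than this note shows. Statements on the series, on what has been measured and on what is new or still open speak of the compounds shown alone.

Compound 1 `Cc1ccc2oc(SCC(=O)Nc3ccc(-c4nc(-c5ccccc5)c(-c5ccccc5)n4C)cc3)nc2c1` and compound 2 `Cn1ccnc1SCC(=O)Nc1ccc(-c2nc(-c3ccccc3)c(-c3ccccc3)n2C)cc1` share one core and differ only in the ring on a sulfur. In a functional assay on HT-29 cells (Homo sapiens) for cytotoxicity, read by MTT assay, with a stated time of 24 h, tested at 32 ug/mL (on this read-out lower numbers stand for a weaker effect and higher numbers for a stronger effect at the one concentration tested), compound 1 gives 59.5%, while compound 2 gives 41.1%, the lower of the two numbers; that step, a number 18.4 percentage points lower from compound 1 to compound 2 (beyond the scatter), is beyond the scatter. Compound 3 `CCN1CCN(CC(=O)Nc2ccc(-c3nc(-c4ccccc4)c(-c4ccccc4)n3C)cc2)CC1` is not yet measured and differs from compound 2 by 4-ethylpiperazin-1-yl in place of (1-methyl-1H-imidazol-2-yl)sulfanyl on a saturated chain carbon bound to a carbonyl carbon. Among the measured compounds shown here, no measured step covers such a swap, so the earlier step is only a loose guide. A small further fall is expected, a number 6.1 percentage points lower from compound 2 to compound 3 (within the scatter). Compound 3 is therefore estimated at 35% in this assay, ranging from 15% to 55%.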

Compound 3, a percentage reported as activity, at one concentration (the size of the read-out at that concentration, not a potency): 38.8%
The estimate for compound 3 lay 3.8 percentage points below the measured number; measured number inside the range.
By their numbers in this assay, from the lowest: compounds 3 and 2 (each within the scatter of the next); then compound 1.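

In this assay, the step of a number 2.3 percentage points lower from compound 2 to compound 3 (within the scatter) shows that a sulfur-linked aromatic ring on this saturated chain carbon can give way to a non-aromatic ring without sulfur and leave no readable difference. The step of a number 20.7 percentage points lower from compound 1 to compound 3 (beyond the scatter) shows the same change made from the (5-methyl-1,3-benzoxazol-2-yl)sulfanyl group, so of these three groups that one alone stands apart. Nothing measured here gives a reason for these numbers.

On these data alone, whether morpholin-4-yl, or piperazine without its ethyl group, would match compound 3 remains open. So does the effect of a carboxylic acid at this place.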